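Inverting the ring stereocentre of compound 3

The compounds below may be only part of what the source reports. "The series", "measured", "known", "first", "only" and "open" are said of these compounds alone.

Compound 3 `O=C(c1ncc(-c2ccccn2)o1)[C@H]1COc2cc(OCc3ccccc3)ccc2C1` is one of three compounds examined in an assay for inhibition of Fatty-acid amide hydrolase 1 (Rattus norvegicus), using a Dixon plot; on this read-out higher numbers stand for weaker inhibition and lower numbers for stronger inhibition. In this assay compound 3 gives 18 nM, the lowest of the two single numbers available; the nearest is compound 2 `O=C(c1ncco1)[C@H]1COc2cc(OCc3ccccc3)ccc2C1`, which gives 20 nM. Compound 1 `COC(=O)c1cccc(-c2cnc(C(=O)C3CCc4cc(Oc5ccccc5)ccc4O3)o2)n1` has two entries, 94 nM; 210 nM (2 entries), and these show how far repeated measurements of a single compound can lie apart (the several entries of compound 1 in this assay, 94 nM; 210 nM (2 entries)). Among the measured compounds shown here, the only step between singly measured compounds is a 1.1-fold lower number from compound 2 to compound 3 (0.05 log units; within the scatter), so adding the pyridin-2-yl group did not move the number beyond the scatter.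

Compound 4 `O=C(c1ncc(-c2ccccn2)o1)[C@@H]1COc2cc(OCc3ccccc3)ccc2C1` has not been measured. It differs from compound 3 in one way: the two compounds have the same atoms and bonds and differ only in configuration as drawn: 1 of 1 stereo elements differ; a stereocentre at a saturated ring carbon is drawn R in compound 3 and S in compound 4. For the measured compounds named here, none of the measured steps concerns a change of configuration, so no step of this kind offers a direct guide; the only calibration is the spread of the two entries of compound 1 (the several entries of compound 1 in this assay, 94 nM; 210 nM (2 entries)). The two configurations could well give quite different numbers, but the data show no direction. The account therefore expects a somewhat higher number for compound 4, with wide uncertainty: compound 4 is estimated at 120 nM, within a range from 15 nM to 1500 nM, corresponding to an expected step of a 6.7-fold higher number from compound 3 to compound 4 (0.82 log units; beyond the scatter).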

Compound 4, inhibition constant: 17 nM
Beside the measured number, compound 4's estimate is 7.1-fold (0.85 log units) above it; the measured number falls inside the stated range.
By their numbers in this assay, from the lowest: compounds 4, 3 and 2 (each within the scatter of the next).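

Inverting the ring stereocentre leaves the number in this assay within the scatter: a 1.1-fold lower number from compound 3 to compound 4 (0.02 log units; within the scatter). Among the compounds shown here, compounds 2 and 3 share one drawn configuration at this centre, so only this new pair tests the position, and for this pair the configuration as drawn makes no difference that the assay can resolve, a comparison that isolates this one change: the fact that compounds 3 and 4 differ only in the configuration as drawn. The two numbers also lie closer together than repeated measurements of one compound can, as shown by: the several entries of compound 1 in this assay, 94 nM; 210 nM (2 entries).

From the compounds shown here alone, it remains open whether the same insensitivity to configuration would hold for a compound without the pyridin-2-yl group, or for one with a carboxylic acid in its place, since this single pair speaks only for the compounds that carry that group. Why the two configurations give numbers within the scatter of each other also stays open, and the result describes this one position and this one assay, not the behaviour of stereocentres across the series as a whole.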